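Swapping Nitro for Chloro on a Benzyl Sulfonamide

The compounds below may be only part of what the source reports. "The series", "measured", "known", "first", "only" and "open" are said of these compounds alone.

Measured compounds:
Compound 1, `COc1ccc(S(=O)(=O)N(Cc2ccccc2C(F)(F)F)[C@H](C)C(=O)NO)cc1`, gives 6 nM.
Compound 2, `COc1ccc(S(=O)(=O)N(Cc2ccc(Cl)c([N+](=O)[O-])c2)[C@H](C)C(=O)NO)cc1`, gives 30 nM.
Compound 3, `COc1ccc(S(=O)(=O)N(Cc2cccc3ccccc23)[C@H](C)C(=O)NO)cc1`, gives 90 nM.

All three were tested in an assay on isolated protein for inhibition of bone morphogenetic protein 1 (Homo sapiens) (a lower number here means a stronger inhibitor, a higher number a weaker inhibitor), and share one core, differing only in the group carried on the benzylic arm. Compound 2 stands second highest of the three numbers: compound 3 gives a higher number, a gap beyond the scatter, while compound 1 gives a lower number, also beyond the scatter.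

Compound 4, `COc1ccc(S(=O)(=O)N(Cc2ccc(Cl)c(Cl)c2)[C@H](C)C(=O)NO)cc1`, has not yet been measured. It differs from compound 2 in one place: chloro in place of nitro on an aromatic carbon. For the measured compounds named here, no step between measured compounds involves this particular change, so the measured set gives no direct guide to its size. Going by the values given here, the three measured compounds show only that the benzylic group can shift the result across a range beyond the scatter. For this change the expectation is a small step in this assay, in either direction, not beyond the usual scatter. Compound 4 is therefore expected to give about 25 nM, with a range from 8 nM to 80 nM. This estimate means an expected step of a 1.2-fold lower number from compound 2 to compound 4 (0.08 log units; within the scatter).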

Compound 4, half-maximal inhibitory concentration: 120 nM
Compound 4: the middle estimate sits 4.8-fold (0.68 log units) below what was measured, and the stated range ends below it.
By their numbers in this assay, from the lowest: compound 1; then compound 2; then compounds 3 and 4 (each within the scatter of the next).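

In this assay, chloro in place of nitro on this aromatic carbon gives a 4.0-fold higher number from compound 2 to compound 4 (0.60 log units; beyond the scatter) and so moves the result by more than repeat measurements would. For the compounds shown here, this is the first comparison here in which only one place changes, so the shift can be tied to this single swap, whereas the earlier compounds differ from one another across the whole benzylic arm. Nothing shown here explains why the step is this large or why it points towards a weaker inhibitor.

As far as these compounds go, whether an amine, a nitrile or a carboxylic acid on this same carbon would land closer to compound 2 or to compound 4 remains open. From the compounds shown here alone, it is also open whether this swap would give a similar step on a benzylic arm without the neighbouring chloro group.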